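Urea in Place of Amide: Expected Recovery of Growth Inhibition

A few compounds are considered here, and "the series" means these few. Any claim that something is new, unique, unknown or untested is made for them only; others in the source may bear on it.

Measured so far:
- compound 1 `COc1cc(-c2nn(-c3cccc(NC(=O)Nc4cc(C(F)(F)F)cc(C(F)(F)F)c4)c3)cc2-c2ccncc2)ccc1Cl`, 1520 nM
- compound 2 `COc1cc(-c2nn(-c3cccc(NC(=O)c4cccc(C(F)(F)F)c4)c3)cc2-c2ccncc2)ccc1Cl`, > 50000 nM

In a functional assay on LOX IMVI cells (Homo sapiens) for inhibition, read by sulforhodamine B assay, with a stated time of 48 h (on this read-out higher numbers stand for weaker inhibition of growth and lower numbers for stronger inhibition of growth), compound 1 gives 1520 nM. Compound 2 reaches only a limit of the assay, > 50000 nM, and so stands at the limit of > 50000 nM in this assay, at which 1 of the 2 values shown sits. Compound 3 `COc1cc(-c2nn(-c3cccc(NC(=O)Nc4ccc(Cl)c(Cl)c4)c3)cc2-c2ccncc2)ccc1Cl` differs from compound 2 by (3,4-dichlorophenyl)amino in place of 3-(trifluoromethyl)phenyl on a carbonyl carbon, which restores the urea link seen in compound 1. Since compound 1 gives 1520 nM, a large step toward stronger growth inhibition is expected, an at least 16-fold lower number from compound 2 to compound 3 (1.22 log units; beyond the scatter). Compound 3 is estimated at 3000 nM, within a range of 800 nM to 20000 nM.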

Compound 3, concentration for total growth inhibition: 2620 nM
For compound 3 the middle estimate is 1.1-fold (0.06 log units) above the measured one; the measured number falls inside the stated range.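

In this assay, putting (3,4-dichlorophenyl)amino in place of 3-(trifluoromethyl)phenyl on a carbonyl carbon gives an at least 19-fold lower number from compound 2 to compound 3 (1.28 log units; beyond the scatter). This step is bounded on one side only, since compound 2 stands at a limit of the assay: the limit of > 50000 nM in this assay, at which 1 of the 3 values shown sits. The urea link now carries measurable growth inhibition with two different aryl groups, the chlorinated ring of compound 3 and the trifluoromethyl-bearing ring of compound 1.

The step changes the link and the ring substituents together, and the compounds shown do not separate the two. On these data alone, how a 3,4-dichlorobenzamide or a carbamate link would read remains open.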